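Chloro to fluoro: what to expect in macrophages

A few compounds are considered here, and "the series" means these few. Any claim that something is new, unique, unknown or untested is made for them only; others in the source may bear on it.

In an ADME assay on cells (Macrophage, Mus musculus) for cytotoxicity, read by resazurin assay, with a stated time of 3 days (a lower number here means a stronger inhibitor, a higher number a weaker inhibitor), compound 1 (`O=C(Nc1cccc(C(F)(F)F)c1)c1cc(Cl)ccc1O`) gives 5900 nM. Compound 2 (`O=C(Nc1ccc(C(F)(F)F)c(C(F)(F)F)c1)c1cc(Cl)ccc1O`) lies close to it at 4900 nM, while compound 3 (`COc1cc(NC(=O)c2cc(Cl)ccc2O)cc(C(F)(F)F)c1`) stands apart at 18000 nM. Compound 4 (`O=C(Nc1cccc(C(F)(F)F)c1)c1cc(F)ccc1O`) has not been measured. Its structure changes in one place: fluoro in place of chloro on an aromatic carbon, with fluoro in place of chloro on an aromatic carbon, para to a hydroxy group. The nearest guides are a 1.2-fold lower number from compound 1 to compound 2 (0.08 log units; within the scatter) and a 3.1-fold higher number from compound 1 to compound 3 (0.48 log units; beyond the scatter). Neither touches the chloro group, so they offer only indirect support for expecting a small change. The expected step is a 1.4-fold higher number from compound 1 to compound 4 (0.13 log units; within the scatter), leaning slightly upward and not clearly beyond the scatter. For compound 4, the estimated value in this assay is 8000 nM, with an expected range of 3500 nM to 18000 nM.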

Compound 4, half-maximal inhibitory concentration: 6100 nM
The estimate for compound 4 lay 1.3-fold (0.12 log units) above the measured number, within the range that was stated.
By their numbers in this assay, from the lowest: compounds 2, 1 and 4 (each within the scatter of the next); then compound 3.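

Within the data shown here, the step for fluoro in place of chloro, para to a hydroxy group, is a 1.0-fold higher number from compound 1 to compound 4 (0.01 log units; within the scatter) in this assay and gives the first direct reading at this position. The earlier steps shown here left the chloro group untouched, whereas this one shows that the two halogens cannot be told apart here. Nothing at hand explains this result.

As far as these compounds go, it remains open whether a group other than a halogen at this position, such as an amine or a carboxylic acid, would shift the number beyond the scatter. Whether the same swap would hold on compound 2 or compound 3 is also unknown.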